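Shifting the fluorine on the phenyl group of compound 3

The source may report more compounds than this note shows. Statements on the series, on what has been measured and on what is new or still open speak of the compounds shown alone.

In a toxicity assay on HUVEC cells (Homo sapiens) for inhibition (on this read-out lower numbers stand for stronger inhibition of growth and higher numbers for weaker inhibition of growth), compound 1 (`Cc1nc(-c2ccccc2)c(C(=O)N2CCN(c3cccc(Cl)c3)CC2)o1`) gives 0.463 ug/mL. Compound 3 (`COc1cc(OC)cc(N2CCN(C(=O)c3oc(C)nc3-c3ccccc3F)CC2)c1`) gives 0.118 ug/mL, and compound 2 (`Cc1nc(-c2ccccc2F)c(C(=O)N2CCN(c3cc(Cl)cc(Cl)c3)CC2)o1`) gives 0.177 ug/mL. The gap between compound 1 and compound 3 lies beyond the scatter, while compound 2 lies within the scatter of compound 3. Compound 4 (`COc1cc(OC)cc(N2CCN(C(=O)c3oc(C)nc3-c3cccc(F)c3)CC2)c1`) differs from compound 3 in one place: 3-fluorophenyl in place of 2-fluorophenyl on an aromatic carbon. Among the compounds with values here, the only measured step, a 1.5-fold lower number from compound 2 to compound 3 (0.18 log units; within the scatter), concerns the group on the amine nitrogen in a ring, and no measured step moves the fluorine. It therefore offers only weak guidance, and no change beyond the scatter is expected. The estimated step is a 1.3-fold higher number from compound 3 to compound 4 (0.10 log units; within the scatter). For compound 4 the expected value is 0.15 ug/mL, with an estimated range from 0.05 ug/mL to 0.45 ug/mL.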

Compound 4, concentration for 50% growth inhibition: 0.126 ug/mL
Compound 4: the middle estimate sits 1.2-fold (0.08 log units) above what was measured; the range from low to high includes it.
By their numbers in this assay, from the lowest: compounds 3, 4 and 2 (each within the scatter of the next); then compound 1.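

Moving the fluorine, with 3-fluorophenyl in place of 2-fluorophenyl on the aromatic carbon next to the ring nitrogen, gives a 1.1-fold higher number from compound 3 to compound 4 (0.03 log units; within the scatter) in this assay. Within the data shown here, this is the first measured step at this position, and it shows that the read-out does not separate these two placements of the fluorine. Nothing available bears on why the two read alike.

As far as these compounds go, it remains open whether a nitrile or an amine on this phenyl group would shift the number beyond the scatter. From the compounds shown here alone, whether the fluorine move behaves the same way alongside the 3,5-dichlorophenyl group of compound 2 is also open.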